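The compounds below may be only part of what the source reports. "The series", "measured", "known", "first", "only" and "open" are said of these compounds alone.

Compound 1 `CC(C)[C@H](NC(=O)COc1cccc2ccccc12)C(=O)N[C@@H](CC(=O)O)C(=O)COc1cc(C(F)(F)F)n(C)n1` gives 46000 nM in a functional assay on Jurkat cells (Homo sapiens) for inhibition; a higher number here means a weaker inhibitor, a lower number a stronger inhibitor. Compound 2 `COC(=O)c1cc(OCC(=O)[C@H](CC(=O)O)NC(=O)[C@@H](NC(=O)COc2cccc3ccccc23)C(C)C)no1` gives 71000 nM in this assay, the higher of the two numbers, its nearest neighbour being compound 1 across a step of a 1.5-fold higher number from compound 1 to compound 2 (0.19 log units; within the scatter). Compound 3 `CC(C)[C@H](NC(=O)COc1cccc2ccccc12)C(=O)N[C@@H](CC(=O)O)C(=O)CSc1ncc[nH]1` differs from compound 2 by (1H-imidazol-2-yl)sulfanyl in place of (5-(methoxycarbonyl)-1,2-oxazol-3-yl)oxy on a saturated chain carbon bound to a carbonyl carbon. Going by the values given here, the single measured step, from compound 1 to compound 2, also exchanged the ring on this chain carbon and stayed within the scatter, but no step touches the sulfur link or the imidazole, so only a small shift is expected. Compound 3 is therefore estimated at 50000 nM, between 15000 nM and 160000 nM, a step of a 1.4-fold lower number from compound 2 to compound 3 (0.15 log units; within the scatter).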

Compound 3, half-maximal inhibitory concentration: > 200000 nM
Compound 3: only a limit was reported; the forecaster's own chance of this, stated with the estimate: 20%; middle value at least 4.0-fold (0.60 log units) away from the limit.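

Going by these compounds alone, at this saturated chain carbon bound to a carbonyl carbon, (1H-imidazol-2-yl)sulfanyl brings the first change beyond the scatter, with an at least 2.8-fold higher number from compound 2 to compound 3 (0.44 log units; beyond the scatter), and against the pyrazole-bearing compound the change is an at least 4.3-fold higher number from compound 1 to compound 3 (0.63 log units; beyond the scatter). The two oxygen-linked rings had stayed within the scatter of each other, so this position does respond to what is placed on it. The value of compound 3 is a limit and not a number, so both steps give only a lower bound on the change: the limit of > 200000 nM in this assay, at which 1 of the 3 values shown sits.

The sulfur link and the imidazole enter together, leaving their shares apart. Going by these compounds, whether a (1H-imidazol-2-yl)oxy group or a phenylsulfanyl group on this carbon would behave like compound 3 remains open.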